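The source may report more compounds than this note shows. Statements on the series, on what has been measured and on what is new or still open speak of the compounds shown alone.

Measured so far:
- compound 1, `CN1C[C@H](C(=O)Nc2cccc(Cl)c2)[C@@H](c2ccc(/C=C/C(=O)Nc3ccccc3N)cc2)C1`: 58 mL/min/kg
- compound 2, `Cc1cccc(NC(=O)[C@H]2CN(C)C[C@@H]2c2ccc(/C=C/C(=O)Nc3ccccc3N)cc2)c1`: 74 mL/min/kg
- compound 3, `CN1C[C@H](C(=O)Nc2ccc(F)c(Cl)c2)[C@@H](c2ccc(/C=C/C(=O)Nc3ccccc3N)cc2)C1`: 34 mL/min/kg

All three were run in an in vitro ADME assay on microsomes from liver (Mus musculus) for pharmacokinetics, read by LC-MS, with a stated time of 10 min, tested at 1 uM; a lower number here means slower removal, a higher number faster removal of the compound. Compound 4, `Cc1cc(NC(=O)[C@H]2CN(C)C[C@@H]2c2ccc(/C=C/C(=O)Nc3ccccc3N)cc2)ccc1F`, has not yet been measured there.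

Compound 4 differs from compound 3 by methyl in place of chloro on an aromatic carbon. The same structural change has already been made once within the series, from compound 1 to compound 2, where it reads (methyl in place of chloro on an aromatic carbon), and in this assay that step came out as a 1.3-fold higher number from compound 1 to compound 2 (0.11 log units; within the scatter). The two cores on which the change is made are not identical: compound 3 differs from compound 1 by fluoro in place of hydrogen on an aromatic carbon. Accordingly the surroundings of the change are not the same word for word. In the earlier pair the place is described only as meta to a large group; in the new pair it is ortho to a fluoro group (1 heavy atom) and meta to a large group. The two changes are therefore the same kind of change rather than the same change.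

Within the series, compound 3 holds the lowest of the three numbers, and its step to compound 2 is given as a 2.2-fold lower number from compound 2 to compound 3 (0.34 log units; beyond the scatter), while its step from compound 1 is a 1.7-fold lower number from compound 1 to compound 3 (0.23 log units; within the scatter).

Going by the values given here, for compound 4 the step from compound 3 in this assay is expected to be a 1.3-fold higher number from compound 3 to compound 4 (0.11 log units; within the scatter), set beside the earlier 1.3-fold higher number from compound 1 to compound 2 (0.11 log units; within the scatter), because that earlier step a 1.3-fold higher number from compound 1 to compound 2 (0.11 log units; within the scatter) is the only precedent for this change. Nothing in the data shows whether the fluoro group at the new place alters the size of the step. On that basis compound 4 is estimated to give 44 mL/min/kg in this assay, with a range of 25 mL/min/kg to 78 mL/min/kg expected.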

Compound 4, clearance: 62 mL/min/kg
Beside the measured number, compound 4's estimate is 1.4-fold (0.15 log units) below it, within the range that was stated.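

In this assay methyl in place of chloro on the core of compound 3 gives a 1.8-fold higher number from compound 3 to compound 4 (0.26 log units; within the scatter), and no difference appears between this step and the one on the core of compound 1: the same change on two cores in this assay, a 1.3-fold higher number (0.11 log units; within the scatter) from compound 1 to compound 2 and a 1.8-fold higher number (0.26 log units; within the scatter) from compound 3 to compound 4, 1.4-fold (0.16 log units) apart, within the scatter of two such steps. Fluoro in place of hydrogen, read here as a 1.2-fold lower number from compound 2 to compound 4 (0.08 log units; within the scatter), likewise shows no difference between the two cores: the same change on two cores in this assay, a 1.7-fold lower number (0.23 log units; within the scatter) from compound 1 to compound 3 and a 1.2-fold lower number (0.08 log units; within the scatter) from compound 2 to compound 4, 1.4-fold (0.16 log units) apart, within the scatter of two such steps. Going by these compounds alone, each of these single steps lies within the scatter, as does a 1.1-fold higher number from compound 1 to compound 4 (0.03 log units; within the scatter), so the four compounds show only that both changes read alike on two cores, not that either change has a real effect of its own or that the agreement would extend to any other core.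

The compounds shown leave open how a methoxy group, a nitrile or a trifluoromethyl group would read in place of the chloro or methyl group. They also leave open whether the steps keep their size when an amine or a carboxylic acid stands in place of the fluoro group.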